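The compounds below may be only part of what the source reports. "The series", "measured", "known", "first", "only" and "open" are said of these compounds alone.

The study measures three compounds in a functional assay on HeLa cells (Homo sapiens) for cytotoxicity, read by WST assay, with a stated time of 48 h (a lower number here means a stronger inhibitor, a higher number a weaker inhibitor), and follows one further change from the best of them. Compound 1, `O[C@@H](c1ccccc1)[C@H]1CO[C@H](c2ccccc2)[C@@H](C/C=C/c2ccccc2)C1`, gives 6060 nM in this assay. Compound 2, `COc1cccc([C@H](O)[C@H]2CO[C@H](c3ccc(OC)c(OC)c3)[C@@H](C/C=C/c3ccc(OC)c(OC)c3)C2)c1`, gives 21200 nM in this assay, and compound 3, `COc1ccc(CCC[C@@H]2C[C@@H]([C@@H](O)c3ccc(OC)c(OC)c3)CO[C@H]2c2ccc(OC)c(OC)c2)cc1OC`, gives 35700 nM in this assay. Among these three numbers compound 1 stands lowest: the nearest of the others is compound 2, whose value is higher by a margin beyond the scatter, and the furthest is compound 3, whose value is higher still, also beyond the scatter. Among the compounds with values here, no single-point step between two measured compounds is available, so the three values show only where each compound lies and not which change drives which difference.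

Compound 4, `O[C@@H](c1ccccc1)[C@H]1CO[C@H](c2ccccc2)[C@@H](C/C=C/c2ccccc2F)C1`, differs from compound 1 in one place: fluoro in place of hydrogen on an aromatic carbon

Within the data shown here, on the evidence given, the change from compound 1 to compound 4 has no counterpart among the measured pairs, so no direction can be read from them. The step of a 1.1-fold lower number from compound 1 to compound 4 (0.04 log units; within the scatter) is expected to stay within the scatter, with no clear direction. Compound 4 is therefore expected to give about 5500 nM in this assay, within a range from 2200 nM to 14000 nM.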

Compound 4, half-maximal inhibitory concentration: 9730 nM
Compound 4: the middle estimate sits 1.8-fold (0.25 log units) below what was measured; measured number inside the range.
By their numbers in this assay, from the lowest: compounds 1 and 4 (each within the scatter of the next); then compounds 2 and 3 (each within the scatter of the next).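

In this assay, the phenyl of the 3-phenylprop-2-en-1-yl chain now has a single-place step of its own: going from phenyl to 2-fluorophenyl, with the fluoro on an aromatic carbon ortho to a large group, gives a 1.6-fold higher number from compound 1 to compound 4 (0.21 log units; within the scatter). Within the data shown here, this is the only direct reading in the set, and it shows that this carbon takes a fluoro in place of hydrogen with no difference that can be told from the scatter, so the value of compound 1 is not visibly tied to the hydrogen there. Nothing available bears on why the step has this size.

One fluoro at one carbon cannot show whether a chloro, a methoxy or a trifluoromethyl on the same carbon would also stay within the scatter, or whether a fluoro elsewhere on that ring would behave alike. It also leaves open what a basic amine or a carboxylic acid at this carbon would do, and whether any change on this ring can move the number beyond the scatter at all.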